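A few compounds are considered here, and "the series" means these few. Any claim that something is new, unique, unknown or untested is made for them only; others in the source may bear on it.

Compound 1 `CO[C@@]1(C(=O)O)C=C[C@@H](NC(C)=O)[C@H]([C@H](O)[C@H](O)CO)O1`: in an assay on HEK293 cells for inhibition of sialidase-3 (Homo sapiens), read by fluorescence, with a stated time of 1 h (a lower number here means a stronger inhibitor, a higher number a weaker inhibitor), compound 1 gives > 1000000 nM, which is a limit of the assay.
Compound 2 `CCS[C@@]1(C(=O)O)C=C[C@@H](NC(C)=O)[C@H]([C@H](O)[C@H](O)CO)O1`: in this assay compound 2 gives > 1000000 nM, also a limit.
Compound 3 `CCCO[C@@]1(C(=O)O)C=C[C@@H](NC(C)=O)[C@H]([C@H](O)[C@H](O)CO)O1`: in this assay compound 3 gives > 1000000 nM, again a limit.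

Among the measured compounds shown here, compound 3 therefore stands at the limit of > 1000000 nM in this assay, at which 3 of the 3 values shown sit, where every measured value shown sits, and no compound here carries a number below that limit. Compound 4 `CC(=O)N[C@@H]1C=C[C@@](OC(C)C)(C(=O)O)O[C@H]1[C@H](O)[C@H](O)CO` differs from compound 3 in one place: isopropyl in place of propyl on an oxygen on a saturated carbon. The step nearest in kind is a step that the two limits leave unreadable from compound 1 to compound 3, which alters the same chain on the same oxygen; a step that the two limits leave unreadable from compound 2 to compound 3 and a step that the two limits leave unreadable from compound 1 to compound 2 are likewise unreadable. With no readable step to draw on, no direction can be expected, and compound 4 is expected to stay at the limit, a step that the limit leaves unreadable from compound 3 to compound 4 being no step beyond the scatter. The estimate for compound 4 is 2000000 nM, within 500000 nM to 10000000 nM.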

Compound 4, half-maximal inhibitory concentration: > 1000000 nM
Compound 4: a limit, no number; the forecaster's own chance of this, stated with the estimate: 90%; the middle value lies beyond the limit too.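

Among the compounds shown here, compound 4 gives > 1000000 nM in this assay, which is a limit, so no step from compound 1, compound 2 or compound 3 to compound 4 can be read. The compounds shown leave open whether changing the group on the shared core alters inhibition at all.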